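The compounds below may be only part of what the source reports. "The series", "measured", "known", "first", "only" and "open" are said of these compounds alone.

Compound 1 `Cc1nc(C)c(CN2CCN(C(=O)c3cccnc3)CC2)nc1C` gives 220000 nM.
Compound 2 `Cc1nc(C)c(CN2CCN(C(=O)C(C)(C)Oc3ccc(Cl)cc3)CC2)nc1C` gives "not determined" (no result reported).
Compound 3 `COc1ccc(OC)c(/C=C/C(=O)N2CCN(Cc3nc(C)c(C)nc3C)CC2)c1` gives 376000 nM.

In a functional assay on ECV-304 cells (Homo sapiens), with stated times of 30 min and 6 h (on this read-out lower numbers stand for an effect already at smaller amounts and higher numbers for an effect only at larger amounts of compound), compound 1 gives 220000 nM and compound 3 gives 376000 nM. These two numbers sit side by side within the usual scatter, so neither compound stands apart from the other. Compound 2 gives "not determined" (no result reported) in this assay. Compound 4 `COc1cccc(/C=C/C(=O)N2CCN(Cc3nc(C)c(C)nc3C)CC2)c1OC` differs from compound 3 by 2,3-dimethoxyphenyl in place of 2,5-dimethoxyphenyl on a double-bonded chain carbon bound to a double-bonded chain carbon. For the measured compounds named here, no step between two measured compounds is available, so there is nothing against which to set the size of this change. The expectation is that the step of a 1.1-fold lower number from compound 3 to compound 4 (0.03 log units; within the scatter) stays within the scatter, with no clear direction. Compound 4 is therefore estimated at 350000 nM, within a range from 150000 nM to 800000 nM.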

Compound 4, half-maximal effective concentration: 340000 nM
For compound 4 the middle estimate is 1.0-fold (0.01 log units) above the measured one; the range from low to high includes it.
By their numbers in this assay, from the lowest: compounds 1, 4 and 3 (each within the scatter of the next).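

For the compounds shown here, putting 2,3-dimethoxyphenyl in place of 2,5-dimethoxyphenyl on a double-bonded chain carbon bound to a double-bonded chain carbon gives the first step that can be read in this assay, and it comes to a 1.1-fold lower number from compound 3 to compound 4 (0.04 log units; within the scatter). For these two arrangements of the same atoms, the read-out therefore shows no clear difference. No supporting measurement bears on this result.

From the compounds shown here alone, it remains open whether an amine or a carboxylic acid on this ring, in place of the two methoxy groups, would shift the number beyond the scatter. The same question stands for a longer chain in place of the double-bonded one.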